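The compounds below may be only part of what the source reports. "The series", "measured", "known", "first", "only" and "open" are said of these compounds alone.

In an assay for inhibition of protein disulfide-isomerase (Homo sapiens), with a stated time of 1 h (on this read-out higher numbers stand for weaker inhibition and lower numbers for stronger inhibition), compound 1 `Cc1ccnc(NC(c2ccccc2F)c2ccc3cccnc3c2O)c1` gives 880 nM. Compound 2 `Cc1ccnc(NC(c2ccc3cccnc3c2O)c2c(F)cccc2Cl)c1` is the same molecule with a chloro in place of hydrogen on an aromatic carbon. Compound 2 reaches only a limit of the assay, > 40000 nM, so its true number is not known. That single change produced an at least 45-fold higher number from compound 1 to compound 2 (1.65 log units; beyond the scatter), and because this step ends at the limit of > 40000 nM in this assay, at which 1 of the 2 values shown sits, its real size could be even larger than the number shown.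

Compound 3 `Cc1ccnc(NC(c2ccccc2)c2ccc3cccnc3c2O)c1` differs from compound 2 by phenyl in place of 2-chloro-6-fluorophenyl on a saturated chain carbon bound to an aromatic carbon and a nitrogen on an aromatic ring. Going by the values given here, this change removes the chloro whose addition caused the large loss seen above, and at the same time removes the fluorine, a change for which no measured pair exists here. Among the compounds with values here, the only measured step that bears on it therefore points to a large recovery in this assay, toward lower numbers, while the effect of losing the fluorine is uncertain. Compound 3 is expected to land near 1500 nM, with a plausible range from 400 nM to 6000 nM. That expectation corresponds to an at least 26-fold lower number from compound 2 to compound 3 (1.42 log units; beyond the scatter).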

Compound 3, half-maximal inhibitory concentration: < 200 nM
Compound 3 was reported as a limit (the forecaster's own chance of this, stated with the estimate: 10%); middle value at least 7.5-fold (0.87 log units) from the limit.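

In this assay, the change to phenyl in place of 2-chloro-6-fluorophenyl on a saturated chain carbon bound to an aromatic carbon and a nitrogen on an aromatic ring gives an at least 200-fold lower number from compound 2 to compound 3 (2.30 log units; beyond the scatter), so this position can move the read-out across a very wide range. The new information is about the fluorine, which had no measured pair of its own until now: hydrogen in place of fluoro on an aromatic carbon gives an at least 4.4-fold lower number from compound 1 to compound 3 (0.64 log units; beyond the scatter), so among these three compounds the bare phenyl ring gives the lowest number, and the chloro is not the only substituent here that raises it. Compound 3 is itself a limit of the assay, so both of these steps could be larger than the sizes shown: the limit of < 200 nM in this assay, at which 1 of the 3 values shown sits.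

The compounds shown leave open how far the true number of compound 3 lies beyond that limit, and how much a chloro alone, with no fluoro on the same ring, would cost. They also leave open whether any group on this phenyl ring can lower the number further, as a methoxy, an amine or a carboxylic acid there might or might not do.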